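The source may report more compounds than this note shows. Statements on the series, on what has been measured and on what is new or still open speak of the compounds shown alone.

Compounds measured so far in an assay on HEK293 cells for negative allosteric modulation of metabotropic glutamate receptor 5 (Homo sapiens), read by FLIPR; a lower number here means a stronger inhibitor, a higher number a weaker inhibitor:
Compound 1, `O=C(C1CCCCC1)N1CC(c2nc(-c3cccc(F)c3)no2)C1`, gives > 10000 nM, a limit of the assay.
Compound 2, `CC1CCCCC1C(=O)N1CC(c2nc(-c3cccc(F)c3)no2)C1`, gives > 10000 nM, likewise a limit.
Compound 3, `O=C(c1ccc(F)c(F)c1)N1CC(c2nc(-c3cccc(F)c3)no2)C1`, gives > 10000 nM, again a limit.

Compound 1 therefore stands only at a limit, (the limit of > 10000 nM in this assay, at which 3 of the 3 values shown sit). The change to compound 4, `O=C(C1CCC(C(F)(F)F)CC1)N1CC(c2nc(-c3cccc(F)c3)no2)C1`, is trifluoromethyl in place of hydrogen on a saturated ring carbon. The measured steps that bear on it, a step that the two limits leave unreadable from compound 1 to compound 2 and a step that the two limits leave unreadable from compound 1 to compound 3, cannot be read in size because both ends sit at the limit, and a step that the two limits leave unreadable from compound 2 to compound 3 is no more readable. No direction beyond the scatter can be expected from these numbers. Compound 4 is estimated at 15000 nM, with a range from 5000 nM to 50000 nM. This estimate means an expected step that the limit leaves unreadable from compound 1 to compound 4 in this assay.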

Compound 4, half-maximal inhibitory concentration: > 10000 nM
Compound 4 ended at the assay's limit (the forecaster's own chance of this, stated with the estimate: 85%); the middle value lies beyond the limit too.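

In this assay, for the compounds shown here, compound 4 gives > 10000 nM, which is a limit, so no step from compound 1 to compound 4 can be read: the limit of > 10000 nM in this assay, at which 4 of the 4 values shown sit. The compounds shown leave open whether any of these changes alters inhibitory strength at all.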